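The compounds below may be only part of what the source reports. "The series", "measured", "known", "first", "only" and "open" are said of these compounds alone.

In a functional assay on the whole organism (strain Swiss) with Mus musculus as the target, in the maximal electroshock model, with a stated time of 0.5 h, at a dose of 300 mg/kg by the intraperitoneal route (a higher number here means a stronger effect of the compound at the dose given, a lower number a weaker effect), compound 1 `COc1cccc(N2CCN(C(=O)C(C)N3C(=O)CCC3=O)CC2)c1` gives 50%, the second highest of the three numbers. Compound 2 `CCC(C(=O)N1CCN(c2cccc(F)c2)CC1)N1C(=O)CCC1=O` gives 100%, a number beyond the scatter above compound 1, while compound 3 `CCC(C(=O)N1CCOCC1)N1C(=O)CCC1=O` gives 0%, beyond the scatter below compound 1. Compound 4 `CC(C(=O)N1CCN(c2ccccc2Cl)CC1)N1C(=O)CCC1=O` has not yet been measured. It differs from compound 1 in one place: 2-chlorophenyl in place of 3-methoxyphenyl on an amine nitrogen in a ring. Going by the values given here, no measured pair shows this change, so its effect has no precedent here. Compound 4 keeps an aromatic ring on the amine nitrogen in a ring, as compound 1 and compound 2 do, and the step is expected to be small, a number 10 percentage points higher from compound 1 to compound 4 (within the scatter), not beyond the scatter in either direction. Compound 4 is therefore expected to give 60%, within a range from 20% to 100%.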

Compound 4, a percentage reported as activity, at one dose (the size of the read-out at that dose, not a potency): 0%
Estimate against measurement, compound 4: 60 percentage points above, and the stated range ends above it.
By their numbers in this assay, from the lowest: compounds 3 and 4 (each within the scatter of the next); then compound 1; then compound 2.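

In this assay, the group on the amine nitrogen in a ring proves decisive: putting 2-chlorophenyl in place of 3-methoxyphenyl gives a number 50 percentage points lower from compound 1 to compound 4 (beyond the scatter) and so a far larger step than a shared aromatic ring there would suggest. An aromatic ring on this nitrogen is therefore not enough to retain the effect at this dose. Nothing available accounts for this loss. The compounds shown leave open whether the chlorine itself or its place on the aromatic ring matters, and what a plain phenyl group on this nitrogen would give.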